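The source may report more compounds than this note shows. Statements on the series, on what has been measured and on what is new or still open speak of the compounds shown alone.

In a functional assay on MIA PaCa-2 cells (Homo sapiens) for inhibition, read by MTT assay, with a stated time of 48 h, tested at 10 uM (a higher number here means more inhibition of growth at the concentration tested, a lower number less inhibition of growth), three compounds sharing part of their core have been measured. Compound 1 `Cc1cc(=O)c2c(O)c(CN3CCN(C(=O)OC(C)(C)C)CC3)c(O)c([C@H]3CCN(C)C[C@H]3O)c2o1` gives 6%, compound 2 `Cc1cc(=O)c2c(O)c(CN(C(C)C)C(C)C)c(O)c([C@H]3CCN(C)C[C@H]3O)c2o1` gives 11%, and compound 3 `Cc1oc2c([C@H]3CCN(C)C[C@H]3O)c(O)cc(O)c2c(=O)c1C(O)c1ccc(Cl)cc1` gives 15%. Compound 3 therefore lies within the usual scatter of both compound 1 and compound 2, and the three numbers cannot be separated. Compound 4 `Cc1oc2c([C@H]3CCN(C)C[C@H]3O)c(O)cc(O)c2c(=O)c1C(O)c1ccccc1Br` differs from compound 3 in a single place: 2-bromophenyl in place of 4-chlorophenyl on a saturated chain carbon bound to an aromatic carbon and an oxygen on a saturated carbon. This puts 2-bromophenyl in place of 4-chlorophenyl on a saturated chain carbon bound to an aromatic carbon and an oxygen on a saturated carbon. Going by the values given here, no measured pair isolates a change of this kind, so the data give no direct guide to its effect. The starting point is compound 3 at 15%, and no shift beyond the scatter is expected in either direction. The expected size of the change is a number 1 percentage points lower from compound 3 to compound 4 (within the scatter). For compound 4 the estimated value is 14%, with an expected range of 3% to 30%.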

Compound 4, percent growth inhibition at one concentration: 10%
The estimate for compound 4 lay 4 percentage points above the measured number; the measured number falls inside the stated range.
By their numbers in this assay, from the lowest: compounds 1, 4, 2 and 3 (each within the scatter of the next).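

Read in this assay the exchange of 2-bromophenyl for 4-chlorophenyl on a saturated chain carbon bound to an aromatic carbon and an oxygen on a saturated carbon gives a number 5 percentage points lower from compound 3 to compound 4 (within the scatter) and is the first step that can be read at this position. The place therefore tolerates a change of both the halogen and its location on the ring without a shift beyond the scatter, although both changed at once and this single step cannot divide between them. Nothing in the data offers an explanation for this result.

The compounds shown leave open whether any group at this place can raise growth inhibition beyond the scatter. An unsubstituted phenyl would show what the halogens contribute, and a phenyl bearing a carboxylic acid or an amine in place of the aryl group would test a far larger change.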